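A few compounds are considered here, and "the series" means these few. Any claim that something is new, unique, unknown or untested is made for them only; others in the source may bear on it.

Working notes on the series.

Compound 1 `COc1ccc(-c2ccc(C)n2-c2ccc(-c3nc4ccccc4s3)cc2)cc1` is the reference. In a functional assay on MDA-MB-231 cells (Homo sapiens) for cytotoxicity, read by sulforhodamine B assay, with a stated time of 48 h (a higher number here means a weaker inhibitor of growth, a lower number a stronger inhibitor of growth), compound 1 gives 3990 nM. Compound 2 `Cc1ccc(-c2ccc([N+](=O)[O-])cc2)n1-c1ccc(-c2nc3ccccc3s2)cc1` differs from compound 1 by nitro in place of methoxy on an aromatic carbon, and in this assay compound 2 gives 3900 nM; the step of a 1.0-fold lower number from compound 1 to compound 2 (0.01 log units; within the scatter) is within the scatter. Compound 3 `COc1ccc(-c2ccc(C)n2-c2ccc(-c3nc4ccc(OC)cc4s3)cc2)cc1` differs from compound 1 by methoxy in place of hydrogen on an aromatic carbon, and in this assay compound 3 gives 4120 nM; the step of a 1.0-fold higher number from compound 1 to compound 3 (0.01 log units; within the scatter) is also within the scatter. The three measured values lie within the scatter of one another, so no ordering among them can be read.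

Compound 4 `COc1ccc2nc(-c3ccc(-n4c(C)ccc4-c4ccc([N+](=O)[O-])cc4)cc3)sc2c1` has not yet been measured. It differs from compound 3 by nitro in place of methoxy on an aromatic carbon, which is the same change that separates compound 2 from compound 1, and it occurs twice among the compounds shown. The place of the change is described in the same words in both cases, so it is taken as the same change on a core that differs only by the methoxy described above.

Within the data shown here, for compound 4 in this assay a step of about a 1.0-fold lower number from compound 3 to compound 4 (0.01 log units; within the scatter) from compound 3 is expected, resting on the single precedent a 1.0-fold lower number from compound 1 to compound 2 (0.01 log units; within the scatter), which was within the scatter. The estimate for compound 4 is 4000 nM, with a range from 2500 nM to 6500 nM.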

Compound 4, concentration for 50% growth inhibition: 4560 nM
Compound 4: the middle estimate sits 1.1-fold (0.06 log units) below what was measured, within the range that was stated.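

In this assay, 4-nitrophenyl in place of 4-methoxyphenyl on the methoxy-bearing core gives a 1.1-fold higher number from compound 3 to compound 4 (0.04 log units; within the scatter), and this step agrees with the earlier one: the same change on two cores in this assay, a 1.0-fold lower number (0.01 log units; within the scatter) from compound 1 to compound 2 and a 1.1-fold higher number (0.04 log units; within the scatter) from compound 3 to compound 4, 1.1-fold (0.05 log units) apart, within the scatter of two such steps. The other change, methoxy in place of hydrogen on an aromatic carbon, gives a 1.2-fold higher number from compound 2 to compound 4 (0.07 log units; within the scatter) on the core carrying the nitro group, and it too agrees with its earlier counterpart: the same change on two cores in this assay, a 1.0-fold higher number (0.01 log units; within the scatter) from compound 1 to compound 3 and a 1.2-fold higher number (0.07 log units; within the scatter) from compound 2 to compound 4, 1.1-fold (0.05 log units) apart, within the scatter of two such steps. Among these compounds, each change therefore reads the same on both cores, but every step lies within the scatter, so this shows only that neither change has a step that can be told from scatter on these two cores, and it does not show that a sizeable effect would carry from one core to another.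

The compounds shown leave open whether any group at these places gives a step beyond the scatter. An amine or a carboxylic acid in the place of the nitro group, or a longer chain in the place of the methoxy group, would test this.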